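Thiophene in place of the dimethylaminophenyl end group

The compounds below may be only part of what the source reports. "The series", "measured", "known", "first", "only" and "open" are said of these compounds alone.

The shared core of compound 1 `Cc1nc(NC(=O)c2ccccc2)sc1C(=O)/C=C/c1ccccc1` carries a styryl-type end group; in an assay for inhibition of Polyunsaturated fatty acid 5-lipoxygenase (Homo sapiens), read by spectrophotometry, tested at 10 uM, in the presence of a further agent that is not named here (on this read-out lower numbers stand for less inhibition and higher numbers for more inhibition at the one concentration tested (going by the name of the read-out)), compound 1 gives 73.5%. Compound 2 `Cc1ccc(/C=C/C(=O)c2sc(NC(=O)c3ccccc3)nc2C)cc1` gives 75.1% in this assay, and the step of a number 1.6 percentage points higher from compound 1 to compound 2 (within the scatter) lies within the scatter. Compound 3 `Cc1nc(NC(=O)c2ccccc2)sc1C(=O)/C=C/c1ccc(N(C)C)cc1` gives 88.2% in this assay, the highest of the three numbers, separated beyond the scatter from both others: the step of a number 14.7 percentage points higher from compound 1 to compound 3 (beyond the scatter) and the step of a number 13.1 percentage points higher from compound 2 to compound 3 (beyond the scatter).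

Compound 4 `Cc1nc(NC(=O)c2ccccc2)sc1C(=O)/C=C/c1cccs1` differs from compound 3 by thiophen-2-yl in place of 4-(dimethylamino)phenyl on a double-bonded chain carbon bound to a double-bonded chain carbon. Within the data shown here, no measured step exchanges one ring for another; the steps that bear on it are those in which the dimethylamino group enters, a number 14.7 percentage points higher from compound 1 to compound 3 (beyond the scatter) and a number 13.1 percentage points higher from compound 2 to compound 3 (beyond the scatter), both modest gains beyond the scatter. Its loss in compound 4 is expected to reverse roughly that gain in this assay, with the thiophene ring itself an unmeasured factor. Compound 4 is therefore expected to give about 74%, between 60% and 86%, a step of a number 14.2 percentage points lower from compound 3 to compound 4 (beyond the scatter) expected to be beyond the scatter downward.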

Compound 4, a percentage reported as inhibition, at one concentration (the size of the read-out at that concentration, not a potency): 71.9%
The estimate for compound 4 lay 2.1 percentage points above the measured number, within the range that was stated.
By their numbers in this assay, from the lowest: compounds 4, 1 and 2 (each within the scatter of the next); then compound 3.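

In this assay, the five-membered thiophen-2-yl end group stands level with the plain phenyl end group (a number 1.6 percentage points lower from compound 1 to compound 4 (within the scatter)) and with 4-methylphenyl (a number 3.2 percentage points lower from compound 2 to compound 4 (within the scatter)), so this place accepts a change from a six-membered ring of carbon only to a five-membered ring with a hetero atom without a readable shift. Only 4-(dimethylamino)phenyl stands apart (a number 16.3 percentage points lower from compound 3 to compound 4 (beyond the scatter)), and among these four end groups the higher number belongs to that group alone. Nothing at hand gives a reason for this difference.

Going by these compounds, whether the higher number is specific to dimethylamino or would also appear with a methoxy group or a primary amine on the phenyl ring remains open. Also open, on these data alone, is whether a dimethylamino group on the thiophen-2-yl ring would raise the number in the same way.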